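Aryl exchange at the saturated ring carbon: compound 4

The source may hold more compounds than are shown below. What is called first, only, known or untested is meant among the compounds shown, and "the series" means these compounds.

The three measured compounds share one core and differ only in the group on a saturated ring carbon: compound 1 `COc1cc(N2C(N)=C(C#N)C(c3cccc([N+](=O)[O-])c3)C3=C2CC(C)(C)CC3=O)cc(OC)c1OC` carries 3-nitrophenyl, compound 2 `COc1cc(N2C(N)=C(C#N)C(c3cccs3)C3=C2CC(C)(C)CC3=O)cc(OC)c1OC` thiophen-2-yl and compound 3 `COc1cc(N2C(N)=C(C#N)C(c3ccccc3Cl)C3=C2CC(C)(C)CC3=O)cc(OC)c1OC` 2-chlorophenyl. In a functional assay on Ehrlich cells (Mus musculus) for cytotoxicity, tested at 50 ug/mL (a higher number here means a stronger effect of the compound at the concentration tested, a lower number a weaker effect), compound 1 gives 30%, compound 2 gives 15% and compound 3 gives 20%. Compound 2 thus holds the lowest of the three numbers, though the gap to compound 3 is a number 5 percentage points higher from compound 2 to compound 3 (within the scatter) and so not a real difference; the gap from compound 1 is a number 15 percentage points lower from compound 1 to compound 2 (beyond the scatter), and between compound 1 and compound 3 the step is a number 10 percentage points lower from compound 1 to compound 3 (within the scatter).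

Compound 4 `COc1ccc(C2C(C#N)=C(N)N(c3cc(OC)c(OC)c(OC)c3)C3=C2C(=O)CC(C)(C)C3)cc1` has not been measured. It differs from compound 2 in one place: 4-methoxyphenyl in place of thiophen-2-yl on a saturated ring carbon.

For the measured compounds named here, the steps that bear on this are the three aryl exchanges at the same saturated ring carbon. Only one of them lies beyond the scatter, and the whole spread among the three numbers is modest. Going by the values given here, no measured step has 4-methoxyphenyl entering, so the direction rests on the general narrowness of the spread. The expected step of a number 7 percentage points higher from compound 2 to compound 4 (within the scatter) is therefore small, most likely upward from the lowest number, and not clearly beyond the scatter.

In this assay compound 4 is expected to give 22%, with a range from 10% to 35%.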

Compound 4, a percentage reported as activity, at one concentration (the size of the read-out at that concentration, not a potency): 11%
For compound 4 the middle estimate is 11 percentage points above the measured one; measured number inside the range.
By their numbers in this assay, from the lowest: compounds 4, 2, 3 and 1 (each within the scatter of the next, the first and the last beyond it).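

With 4-methoxyphenyl as a fourth group on the saturated ring carbon, two of the new exchanges in this assay stay small: a number 4 percentage points lower from compound 2 to compound 4 (within the scatter) and a number 9 percentage points lower from compound 3 to compound 4 (within the scatter), so thiophen-2-yl, 2-chlorophenyl and 4-methoxyphenyl cannot be told apart at this position. The 3-nitrophenyl group of compound 1 now has a second step beyond the scatter, a number 19 percentage points lower from compound 1 to compound 4 (beyond the scatter), which adds to the earlier a number 15 percentage points lower from compound 1 to compound 2 (beyond the scatter); compound 3 goes against a clean separation of compound 1 from the other three, since a number 10 percentage points lower from compound 1 to compound 3 (within the scatter). Nothing measured on these groups accompanies the numbers, so the data offer no explanation of why 3-nitrophenyl stands apart from thiophen-2-yl and 4-methoxyphenyl.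

As far as these compounds go, all four groups at this carbon are aromatic rings, so the effect of a cyclohexyl ring, a plain methyl, or a phenyl carrying a carboxylic acid or a dimethylamino group remains open. Also open, from the compounds shown here alone, is whether a second nitro-bearing aryl group would repeat the number of compound 1, and whether a carboxamide in place of the cyano group would shift the read-out in this assay.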